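A few compounds are considered here, and "the series" means these few. Any claim that something is new, unique, unknown or untested is made for them only; others in the source may bear on it.

Compound 1 `Clc1ccccc1COc1ccccc1/C=C/C(/C=C/c1ccccn1)=N/Oc1ncnc2ccccc12` and compound 2 `Cc1cccc2ncnc(O/N=C(\C=C\c3ccccn3)/C=C/c3ccccc3OCc3ccccc3Cl)c12` differ in a single place: methyl in place of hydrogen on an aromatic carbon. In a functional assay on SMMC-7721 cells (Homo sapiens) for inhibition, read by MTT assay, with a stated time of 72 h, tested at 10 uM (on this read-out higher numbers stand for a stronger effect at the one concentration tested and lower numbers for a weaker effect), compound 1 gives 96%, and compound 2 gives 95.7%, so the step is a number 0.3 percentage points lower from compound 1 to compound 2 (within the scatter). Compound 3 `Clc1ccccc1COc1ccc(/C=C/C(/C=C/c2ccccn2)=N/Oc2ncnc3ccccc23)cc1` has a core that differs from the core of compound 1, a difference that is not broken down here; in this assay compound 3 gives 96.9%, a number within the scatter of those of compound 1 and compound 2. Compound 4 `Cc1cccc2ncnc(O/N=C(/C=C/c3ccc(OCc4ccccc4Cl)cc3)\C=C\c3ccccn3)c12` has not yet been measured. It differs from compound 3 by methyl in place of hydrogen on an aromatic carbon, the same change at the same place as between compound 1 and compound 2. Compound 4 is therefore expected to give 96.5%, with a range from 91% to 99%, because the same change earlier produced a number 0.3 percentage points lower from compound 1 to compound 2 (within the scatter). This amounts to an estimated step of a number 0.4 percentage points lower from compound 3 to compound 4 (within the scatter).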

Compound 4, a percentage reported as inhibition, at one concentration (the size of the read-out at that concentration, not a potency): 84.7%
Beside the measured number, compound 4's estimate is 11.8 percentage points above it, outside the stated range (below it).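

In this assay, the change from quinazolin-4-yl to 5-methylquinazolin-4-yl on the core of compound 3 gives a number 12.2 percentage points lower from compound 3 to compound 4 (beyond the scatter). Set beside the earlier step, the two do not clearly differ: the same change on two cores in this assay, a number 0.3 percentage points lower (within the scatter) from compound 1 to compound 2 and a number 12.2 percentage points lower (beyond the scatter) from compound 3 to compound 4, 11.9 percentage points apart, within the scatter of two such steps. So the methyl is followed by a fall beyond the scatter on this one core, but these two steps show neither that the core alters the effect of the methyl nor that the change carries over with a fixed size.

The compounds shown leave open how an ethyl group, a methoxy group or a chlorine atom would read at this same place. They also leave open whether a similar step would appear on further cores.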